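The source may report more compounds than this note shows. Statements on the series, on what has been measured and on what is new or still open speak of the compounds shown alone.

Measured in a functional assay on HEp-2 cells (Homo sapiens) for antiproliferative activity, read by MTT assay, with a stated time of 72 h (on this read-out higher numbers stand for weaker inhibition and lower numbers for stronger inhibition), so far:
- Compound 1 `O=c1cc(CSC(=S)N2CCCC2)oc2cc(Cl)ccc12` sits at a limit of this assay, > 40000 nM.
- Compound 2 `O=c1c(CSC(=S)N2CCOCC2)coc2cc(Cl)ccc12` gives 900 nM.
- Compound 3 `O=c1c(CSC(=S)N2CCCCC2)coc2cc(Cl)ccc12` gives 280 nM.

Compound 2 holds the highest of the two numbers reported; its nearest neighbour is compound 3, reached by a 3.2-fold lower number from compound 2 to compound 3 (0.51 log units; beyond the scatter). The remaining entry is only a limit, (the limit of > 40000 nM in this assay, at which 1 of the 3 values shown sits).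

Compound 4 `O=c1c(CSC(=S)N2CCOCC2)coc2ccccc12` differs from compound 2 by hydrogen in place of chloro on an aromatic carbon. For the measured compounds named here, no measured step touches that position: the single step on record, a 3.2-fold lower number from compound 2 to compound 3 (0.51 log units; beyond the scatter), alters the ring on the thiocarbonyl carbon and leaves the chloro untouched, so it gives no direct guide. The change is expected to shift this assay little, a 1.7-fold higher number from compound 2 to compound 4 (0.22 log units; within the scatter), with a wide margin. Compound 4 is therefore estimated at 1500 nM, between 500 nM and 5000 nM.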

Compound 4, half-maximal inhibitory concentration: 4400 nM
Compound 4: the middle estimate sits 2.9-fold (0.47 log units) below what was measured, and the stated range covers the measured number.
By their numbers in this assay, from the lowest: compound 3; then compound 2; then compound 4. At a limit, above all of these: compound 1.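

Hydrogen in place of chloro on the aromatic carbon gives a 4.9-fold higher number from compound 2 to compound 4 (0.69 log units; beyond the scatter) in this assay, so this position, untouched by the earlier step, does bear on the read-out. The step is read only with morpholin-4-yl on the thiocarbonyl carbon. Nothing shown here accounts for the size of this step.

As far as these compounds go, whether the chloro counts in the same way with piperidin-1-yl on the thiocarbonyl carbon remains open. Also open, from the compounds shown here alone, is how fluoro, bromo, methoxy or an amine would read at this same aromatic carbon.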